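From methoxy to cyclohexylmethoxy on a shared core

The source may report more compounds than this note shows. Statements on the series, on what has been measured and on what is new or still open speak of the compounds shown alone.

Measured so far in a physicochemical assay for solubility, read by nephelometry, in phosphate buffer, measured as kinetic solubility, with a stated time of 1 h; on this read-out lower numbers stand for lower solubility and higher numbers for higher solubility:
- compound 1 `C=C1CN(S(=O)(=O)c2ccc(C)cc2)CCc2cc(OCC)cc(n2)CCN(S(=O)(=O)c2ccc(C)cc2)C1`: 54000 nM
- compound 2 `C=C1CN(S(=O)(=O)c2ccc(C)cc2)CCc2cc(OC)cc(n2)CCN(S(=O)(=O)c2ccc(C)cc2)C1`: 64000 nM

Going by the values given here, with only two numbers to compare, compound 2 cannot be ranked against compound 1, since the gap between them is no larger than repeat measurements would give. The measured step is a 1.2-fold higher number from compound 1 to compound 2 (0.07 log units; within the scatter). The next compound, compound 3 `C=C1CN(S(=O)(=O)c2ccc(C)cc2)CCc2cc(OCC3CCCCC3)cc(n2)CCN(S(=O)(=O)c2ccc(C)cc2)C1`, starts from compound 2 and changes the same place: cyclohexyl in place of hydrogen on a saturated chain carbon bound to an oxygen on an aromatic ring. In words, cyclohexyl takes the place of hydrogen on a saturated chain carbon bound to an oxygen on an aromatic ring, turning methoxy into cyclohexylmethoxy.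

Among the compounds with values here, only the step between compound 1 and compound 2 bears on this, and it swaps just methyl for hydrogen. Within the data shown here, it offers a weak guide, since no measured compound carries a group as large as cyclohexyl. A moderate move towards a lower number is therefore expected, held with wide uncertainty. The expected step is a 2.6-fold lower number from compound 2 to compound 3 (0.41 log units; beyond the scatter). For compound 3 the estimate is 25000 nM, with an expected range from 7000 nM to 65000 nM.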

Compound 3, solubility: 65000 nM
Estimate against measurement, compound 3: 2.6-fold (0.41 log units) below; the range from low to high includes it.
By their numbers in this assay, from the lowest: compounds 1, 2 and 3 (each within the scatter of the next).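

On this saturated chain carbon bound to an oxygen on an aromatic ring, the earlier pair compared only a methyl with a hydrogen, whereas a cyclohexyl of 6 heavy atoms now stands there, and in this assay the step is a 1.0-fold higher number from compound 2 to compound 3 (0.01 log units; within the scatter) even with this much larger group. Set against the methyl of compound 1, the same group gives a 1.2-fold higher number from compound 1 to compound 3 (0.08 log units; within the scatter) and so all three compounds lie within the scatter of one another, which means this read-out does not tell a hydrogen, a methyl and a cyclohexyl apart at this place. No other measurement is available to explain this outcome.

Whether an amine, a carboxylic acid or a longer chain on this carbon would also read the same stays open, as every group shown here is built of carbon only. The shared core is also identical in all three compounds, so the compounds shown say nothing about whether this result would hold with a change elsewhere on that core.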